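This account rests on a few compounds, and the source may have more. Where it says the series, first, only, none or still open, it means among the compounds named here.

Compound 1 `CCOc1ccc(NC2=CC(=O)c3c(nc4n3[C@H]3OC[C@@H](O)[C@H]3OC4)C2=O)cc1` gives 2090 nM in a functional assay on MGC-803 cells (Homo sapiens) for inhibition, read by sulforhodamine B assay; a higher number here means a weaker inhibitor, a lower number a stronger inhibitor. For the measured compounds named here, compound 2 `COc1ccc(NC2=CC(=O)c3nc4n(c3C2=O)[C@H]2OC[C@@H](O)[C@H]2OC4)cc1` gives 1680 nM in this assay, a number within the usual scatter of the one for compound 1. Compound 3 `O=C1C=C(N2CCCCC2)C(=O)c2c1nc1n2[C@H]2OC[C@@H](O)[C@H]2OC1` reaches only a limit in this assay, > 8000 nM. That limit, (the limit of > 8000 nM in this assay, at which 1 of the 3 values shown sits), sets the size of the step of an at least 4.7-fold higher number from compound 2 to compound 3 (0.67 log units; beyond the scatter), the only move beyond the scatter in the set so far.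

Compound 4 `O=C1C(Nc2ccc(C(F)(F)F)cc2)=CC(=O)c2c1nc1n2[C@H]2OC[C@@H](O)[C@H]2OC1` differs from compound 1 by trifluoromethyl in place of ethoxy on an aromatic carbon. Going by the values given here, no measured step touches that group; the one step beyond the scatter concerns the whole amino substituent, not its para position. The expectation for compound 4 is therefore no change beyond the scatter, a 1.0-fold lower number from compound 1 to compound 4 (0.02 log units; within the scatter). Compound 4 is estimated at 2000 nM in this assay, within 800 nM to 5000 nM.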

Compound 4, half-maximal inhibitory concentration: 1860 nM
Compound 4: the middle estimate sits 1.1-fold (0.03 log units) above what was measured; the measured number falls inside the stated range.
By their numbers in this assay, from the lowest: compounds 2, 4 and 1 (each within the scatter of the next). At a limit, above all of these: compound 3.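

In this assay, trifluoromethyl in place of ethoxy on this aromatic carbon gives a 1.1-fold lower number from compound 1 to compound 4 (0.05 log units; within the scatter). For the compounds shown here, the position therefore accepts a swap from an oxygen-linked chain to a fluorinated carbon group without a step beyond the scatter, which the earlier compounds, all with oxygen-linked groups or no such ring at all, did not show. Nothing available bears on why this step is so small.

Still open, going by these compounds, is whether a basic amine, a carboxylic acid or a longer alkoxy chain at this position would also stay within the scatter. The same question holds for plain hydrogen there.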